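The compounds below may be only part of what the source reports. "The series", "measured", "known", "first", "only" and "open" are said of these compounds alone.

Measured so far in a functional assay on THP-1 cells (Homo sapiens) for cytotoxicity, read by MTT assay, with a stated time of 24 h; on this read-out lower numbers stand for stronger inhibition and higher numbers for weaker inhibition:
- compound 1 `COc1cc(/C=C2\CN(C)C/C(=C\c3ccc(Br)cc3)C2=O)cc(OC)c1` gives 4270 nM
- compound 2 `COc1cc(/C=C2\CN(C)C/C(=C\c3ccc(C#N)cc3)C2=O)cc(OC)c1` gives 940 nM
- compound 3 `COc1cc(/C=C2\CN(C)C/C(=C\c3cc(OC)c(OC)c(OC)c3)C2=O)cc(OC)c1` gives 720 nM

Compound 3 sits within the scatter of compound 2, and both lie clearly under compound 1. The next compound is compound 4 `COc1cc(/C=C2\CN(C)C/C(=C\c3cccc([N+](=O)[O-])c3)C2=O)cc(OC)c1OC`, reached from compound 3 by 3-nitrophenyl in place of 3,5-dimethoxyphenyl on a double-bonded chain carbon bound to a double-bonded ring carbon, with 3-nitrophenyl in place of 3,5-dimethoxyphenyl. Among the measured compounds shown here, the only measured step, a 4.5-fold lower number from compound 1 to compound 2 (0.66 log units; beyond the scatter), exchanges other groups and so bears on this change only loosely. It offers no firm direction for this change in this assay. The expected result is a 1.3-fold higher number from compound 3 to compound 4 (0.10 log units; within the scatter), with no step beyond the scatter anticipated. For compound 4 the estimated value is 900 nM, with an expected range of 300 nM to 2800 nM.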

Compound 4, half-maximal inhibitory concentration: 890 nM
For compound 4 the middle estimate is 1.0-fold (0.00 log units) above the measured one; the measured number falls inside the stated range.
By their numbers in this assay, from the lowest: compounds 3, 4 and 2 (each within the scatter of the next); then compound 1.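

In this assay, 3-nitrophenyl in place of 3,5-dimethoxyphenyl on a double-bonded chain carbon bound to a double-bonded ring carbon gives a 1.2-fold higher number from compound 3 to compound 4 (0.09 log units; within the scatter). This place therefore accepts two differently substituted aromatic rings with no separation in this read-out, unlike the bromo-to-cyano exchange, which was beyond the scatter. Nothing available here explains this result.

Still open, on these data alone, is whether an aminomethyl or carboxylic acid group on the phenyl ring at this place would stay within the same range. An unsubstituted phenyl ring there is equally unresolved.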